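The source may report more compounds than this note shows. Statements on the series, on what has been measured and on what is new or still open speak of the compounds shown alone.

Values in a functional assay on CCRF-CEM cells (Homo sapiens) for inhibition; a lower number here means a stronger inhibitor, a higher number a weaker inhibitor:
- compound 1 `OC[C@H]1OC(n2cnc3c(-c4ccc(Cl)cc4)ncnc32)[C@H](O)[C@@H]1O`: 900 nM
- compound 2 `Cc1csc(-c2ncnc3c2ncn3C2O[C@H](CO)[C@@H](O)[C@H]2O)c1`: 2900 nM

Compound 2 has the higher of the two numbers in this assay, making it the weaker inhibitor of the pair. The next compound is compound 3 `OC[C@H]1OC(n2cnc3c(-c4cc5ccccc5o4)ncnc32)[C@H](O)[C@@H]1O`, which carries 1-benzofuran-2-yl in place of 4-methylthiophen-2-yl on an aromatic carbon.

Among the measured compounds shown here, only one measured step bears on this change: a 3.2-fold higher number from compound 1 to compound 2 (0.51 log units; beyond the scatter). It is modest and involves a substituent swap at the same place. For the measured compounds named here, no measured compound carries 1-benzofuran-2-yl, so this step suggests a size but no direction. A shift of similar size either way remains possible, but the central expectation is no step beyond the scatter.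

For compound 3 the estimated value is 2000 nM, with an expected range of 500 nM to 8000 nM. The estimated step is a 1.5-fold lower number from compound 2 to compound 3 (0.16 log units; within the scatter).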

Compound 3, half-maximal inhibitory concentration: 15000 nM
Beside the measured number, compound 3's estimate is 7.5-fold (0.88 log units) below it; the whole stated range lies below it.
By their numbers in this assay, from the lowest: compound 1; then compound 2; then compound 3.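

In this assay, this position on the six-membered aromatic ring with 2 nitrogen now shows a direction for 1-benzofuran-2-yl: replacing 4-methylthiophen-2-yl gives a 5.2-fold higher number from compound 2 to compound 3 (0.71 log units; beyond the scatter), and replacing 4-chlorophenyl gives a 17-fold higher number from compound 1 to compound 3 (1.22 log units; beyond the scatter). The position is therefore sensitive to which aromatic group it carries, and compound 3, with its added six-membered aromatic ring of carbon only, is the weakest inhibitor of the three. Nothing available explains this loss.

Between compound 2 and compound 3, the fused ring and the ring oxygen in place of sulfur enter together, so their contributions remain unseparated; an unfused furan-2-yl or a fused 1-benzothiophen-2-yl would help divide them. Also open, on these data alone, is how the position responds to a non-aromatic group, such as an amine or a longer alkyl chain.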